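A few compounds are considered here, and "the series" means these few. Any claim that something is new, unique, unknown or untested is made for them only; others in the source may bear on it.

Measured so far:
Compound 1, `COc1ccc(/C=C/C(=O)c2ccccc2-c2cccc(F)c2)cc1`: 140 nM
Compound 2, `COc1ccc(/C=C/C(=O)c2ccccc2-c2cccc(F)c2)cc1OC`: 160 nM
Compound 3, `COc1ccc(C(=O)/C=C/c2ccccc2-c2ccc(F)cc2)cc1`: 8400 nM

In a functional assay on SW480 cells (Homo sapiens) for antiproliferative activity, read by sulforhodamine B assay, with a stated time of 48 h (on this read-out lower numbers stand for stronger inhibition and higher numbers for weaker inhibition), compound 1 gives 140 nM and compound 2 gives 160 nM. The two differ by one change, (methoxy in place of hydrogen on an aromatic carbon), which produced a 1.1-fold higher number from compound 1 to compound 2 (0.06 log units; within the scatter). Compound 3 is built from the same atoms as compound 1, joined differently; how the two cores differ is not broken down here. In this assay compound 3 gives 8400 nM, a far weaker result than either of the others.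

Compound 4, `COc1ccc(C(=O)/C=C/c2ccccc2-c2ccc(F)cc2)cc1OC`, has not yet been measured. It differs from compound 3 by methoxy in place of hydrogen on an aromatic carbon, the same change as between compound 1 and compound 2. A step within the scatter is expected, because a 1.1-fold higher number from compound 1 to compound 2 (0.06 log units; within the scatter) was within the scatter, although one earlier pair is thin evidence. Compound 4 is therefore estimated at 9000 nM, between 3500 nM and 25000 nM, which means an expected 1.1-fold higher number from compound 3 to compound 4 (0.03 log units; within the scatter).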

Compound 4, half-maximal inhibitory concentration: 8300 nM
Compound 4: the middle estimate sits 1.1-fold (0.04 log units) above what was measured, within the range that was stated.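

In this assay, adding the methoxy group gives a 1.0-fold lower number from compound 3 to compound 4 (0.01 log units; within the scatter), so here too the change leaves the number effectively unmoved. Set beside the earlier step, the two results agree: the same change on two cores in this assay, a 1.1-fold higher number (0.06 log units; within the scatter) from compound 1 to compound 2 and a 1.0-fold lower number (0.01 log units; within the scatter) from compound 3 to compound 4, 1.2-fold (0.06 log units) apart, within the scatter of two such steps. This shows that the change carries over between these two cores with no readable effect on either, but two pairs in one cell assay cannot show that it would do the same on any other core in the series.

The compounds shown leave open what a different group would do in place of the methoxy, such as an amine, a carboxylic acid or a longer chain like butoxy. On these data alone, whether either core would respond to such a group also remains unknown.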